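The source may hold more compounds than are shown below. What is called first, only, known or untested is meant among the compounds shown, and "the series" means these compounds.

Measured compounds:
- compound 1, `c1ccc(-c2cn3ccnc3c(-c3ccc4ncn(C5CCCCC5)c4c3)n2)cc1`: in a functional assay on MOLT-4 cells (Homo sapiens) for inhibition, read by sulforhodamine B assay, with a stated time of 48 h, tested at 10 uM (on this read-out higher numbers stand for more inhibition at the one concentration tested (going by the name of the read-out) and lower numbers for less inhibition), compound 1 gives 67.7%
- compound 2, `CC(=O)c1ccc(-c2cn3ccnc3c(-c3ccc4ncn(C5CCCCC5)c4c3)n2)cc1`: compound 2 gives 14.3%
- compound 3, `c1csc(-c2cn3ccnc3c(-c3ccc4ncn(C5CCCCC5)c4c3)n2)c1`: compound 3 gives 30.8%

Compound 3 stands second highest of the three numbers. Its thiophen-2-yl ring in place of the phenyl of compound 1 brought a number 36.9 percentage points lower from compound 1 to compound 3 (beyond the scatter), while against compound 2 the step is a number 16.5 percentage points higher from compound 2 to compound 3 (beyond the scatter).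

Compound 4, `FC(F)(F)c1cccc(-c2cn3ccnc3c(-c3ccc4ncn(C5CCCCC5)c4c3)n2)c1`, differs from compound 3 in one place: 3-(trifluoromethyl)phenyl in place of thiophen-2-yl on an aromatic carbon. This partly reverses the change seen in a number 36.9 percentage points lower from compound 1 to compound 3 (beyond the scatter), since a six-membered carbon ring returns, but it also adds a substituent to that ring, and the only substituted phenyl measured, compound 2, gave the steep fall a number 53.4 percentage points lower from compound 1 to compound 2 (beyond the scatter). Going by the values given here, no trifluoromethyl-bearing compound has been measured, so the two precedents pull in opposite directions.

Weighing both, compound 4 is expected to land above compound 3 but short of compound 1, a step estimated as a number 14.2 percentage points higher from compound 3 to compound 4 (beyond the scatter). The estimate for compound 4 is 45%, with a range from 20% to 70%.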

Compound 4, a percentage reported as inhibition, at one concentration (the size of the read-out at that concentration, not a potency): 32.9%
Beside the measured number, compound 4's estimate is 12.1 percentage points above it; low and high end bracket the measured number.
By their numbers in this assay, from the lowest: compound 2; then compounds 3 and 4 (each within the scatter of the next); then compound 1.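

In this assay, a phenyl ring at this position does not by itself keep the higher level of compound 1: adding trifluoromethyl gives a number 34.8 percentage points lower from compound 1 to compound 4 (beyond the scatter), so a second substituted phenyl also falls well short of the unsubstituted one. The step of a number 2.1 percentage points higher from compound 3 to compound 4 (within the scatter) leaves 3-(trifluoromethyl)phenyl and thiophen-2-yl indistinguishable in this assay, despite their different rings. Substituted phenyls are not all equal here either, as shown by a number 18.6 percentage points higher from compound 2 to compound 4 (beyond the scatter), although that step changes both the substituent and its place on the ring.

Nothing available explains these steps. As far as these compounds go, it remains open whether an amine or a methoxy group on the phenyl would stay near compound 1, and whether moving trifluoromethyl elsewhere on that ring would alter the result.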